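This account rests on a few compounds, and the source may have more. Where it says the series, first, only, none or still open, it means among the compounds named here.

Measured compounds:
compound 1, `CC[C@H](C)[C@H](NC(=O)CN(c1nc(Cl)nc2[nH]cnc12)C1CC1)C(=O)O`: 36%
compound 2, `CSCC[C@H](NC(=O)CN(c1ncnc2c1ncn2C1CCCCO1)C1CC1)C(=O)OCc1ccccc1`: 41%

Both numbers come from a functional assay on the whole organism (Tail, strain ICR) with Mus musculus as the target, in the tail flick test, with a stated time of 60 min, at a dose of 25 umol/kg by the oral route; on this read-out higher numbers stand for a stronger effect at the one dose given and lower numbers for a weaker effect. In this assay compound 1 gives 36% and compound 2 gives 41%; the two values lie within the usual scatter of each other, so neither can be set apart from the other on these numbers alone. Going by the values given here, the two compounds differ in several places at once, so no single step between them is known.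

The unmeasured compound 3, `C[C@H](NC(=O)CN(c1nc(Cl)nc2[nH]cnc12)C1CC1)C(=O)O`, keeps the core of compound 1 and changes one group: methyl in place of sec-butyl on a saturated chain carbon bound to an amide-type nitrogen and a carbonyl carbon. Among the compounds with values here, with no measured step of a single change to lean on, the expected step from compound 1 to compound 3 in this assay is a small one, a number 6 percentage points lower from compound 1 to compound 3 (within the scatter), not clearly beyond the scatter, and if anything expected to run a little lower. For compound 3 the estimate in this assay is 30%, with a range from 15% to 45%.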

Compound 3, a percentage reported as activity, at one dose (the size of the read-out at that dose, not a potency): 44.6%
The estimate for compound 3 lay 14.6 percentage points below the measured number; measured number inside the range.
By their numbers in this assay, from the lowest: compounds 1, 2 and 3 (each within the scatter of the next).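

Methyl in place of sec-butyl, on a saturated chain carbon bound to an amide-type nitrogen and a carbonyl carbon, gives a number 8.6 percentage points higher from compound 1 to compound 3 (within the scatter) in this assay and offers the first comparison that isolates a single place. At this position, the sec-butyl group can therefore give way to the much smaller methyl with no difference that stands clear of the usual scatter. This holds only for the one dose and time tested, and nothing measured here speaks to what lies behind the result.

From the compounds shown here alone, how a hydroxymethyl group, an aminobutyl chain or a longer chain would read at this position remains open. Also open, going by these compounds, are whether the same change would read alike on the core of compound 2, and how compound 1 and compound 3 would compare at other doses.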